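The source may report more compounds than this note shows. Statements on the series, on what has been measured and on what is new or still open speak of the compounds shown alone.

Measured so far in a functional assay for activation of Alpha-1B adrenergic receptor (Homo sapiens), read by calcium flux; on this read-out higher numbers stand for larger maximal responses and lower numbers for smaller maximal responses:

Compound 1 `c1c[nH]c(-c2ccccc2OCC2=NCCN2)c1` — compound 1 gives 104%.
Compound 2 `c1ccc(-c2ccns2)c(OCC2=NCCN2)c1` — compound 2 gives 56%.

Compound 2 stands lowest of the two numbers; the nearest is compound 1, whose value lies above it by a margin beyond the scatter. For the measured compounds named here, the one measured step, a number 48 percentage points lower from compound 1 to compound 2 (beyond the scatter), came with 1,2-thiazol-5-yl in place of 1H-pyrrol-2-yl on an aromatic carbon.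

Compound 3 `c1ccc(-c2nccs2)c(OCC2=NCCN2)c1` is not yet measured. It differs from compound 2 in this way: 1,3-thiazol-2-yl in place of 1,2-thiazol-5-yl on an aromatic carbon. The two compounds hold the same atoms, joined differently.

Going by the values given here, no measured step exchanges one 1,3-thiazol-2-yl or 1,2-thiazol-5-yl for the other; the single step from compound 1 to compound 2 concerns 1H-pyrrol-2-yl and so bears only indirectly on this change. With nothing in the series to anchor the direction, the step of a number 4 percentage points higher from compound 2 to compound 3 (within the scatter) is expected to stay small, within or close to the scatter. Compound 3 is therefore estimated at 60%, with a range from 35% to 90%, and the measured value will decide.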

Compound 3, largest response reached (reported as maximum), in percent of the reference or control that the assay uses: 100%
The estimate for compound 3 lay 40 percentage points below the measured number, and the stated range ends below it.
By their numbers in this assay, from the lowest: compound 2; then compounds 3 and 1 (each within the scatter of the next).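

In this assay, moving from one thiazole arrangement to the other on the same aromatic carbon gives a number 44 percentage points higher from compound 2 to compound 3 (beyond the scatter), although the group that leaves and the group that enters hold the same atoms and the same counted features. At this position, then, the maximal response follows how the ring atoms are joined, and not merely which atoms the ring holds. The other new step, a number 4 percentage points lower from compound 1 to compound 3 (within the scatter), leaves 1,3-thiazol-2-yl and 1H-pyrrol-2-yl indistinguishable on this read-out, so replacing the 1H-pyrrol-2-yl group with a thiazole does not by itself lower the response, and among the three compounds only the 1,2-thiazol-5-yl group of compound 2 stands apart. Nothing available explains the difference between the two thiazole groups.

Still open, as far as these compounds go, is whether the high response extends beyond these five-membered rings at this place, for example to a plain phenyl, a carboxylic acid or a dimethylamino group. The compounds shown also leave open whether the large gap between the two thiazole groups persists with a further substituent on the six-membered ring of the shared core.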